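A Bromophenyl Variant Checked for Toxicity to Cells

The compounds below may be only part of what the source reports. "The series", "measured", "known", "first", "only" and "open" are said of these compounds alone.

For the measured compounds named here, the three compounds measured so far share one core and differ only in the aromatic groups hung on it. Compound 1 is `COc1ccccc1-c1cnc(NC(=O)c2ccc(F)cc2)n1C`. In a toxicity assay on THP-1 cells (Homo sapiens) for inhibition (on this read-out lower numbers stand for higher toxicity in this test and higher numbers for lower toxicity in this test), compound 1 reaches only > 100000 nM, which is a limit of the test and not a measured number. Compound 2, `COc1ccc(-c2cnc(NC(=O)c3ccccc3F)n2C)cc1`, likewise stops at the limit, giving > 100000 nM in this assay. Compound 3, `COc1ccc(-c2cnc(NC(=O)c3ccccn3)n2C)cc1`, also gives a limit, > 100000 nM, in this assay. The step that the two limits leave unreadable from compound 2 to compound 3 cannot be sized because the limit of > 100000 nM in this assay, at which 3 of the 3 values shown sit, leaves both of its ends open.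

Compound 4 is `Cn1c(-c2cccc(Br)c2)cnc1NC(=O)c1ccc(F)cc1`. It differs from compound 1 by 3-bromophenyl in place of 2-methoxyphenyl on an aromatic carbon. Going by the values given here, no measured step covers this change, and every measured value sits at the same limit, so nothing points to a step beyond the usual scatter in either direction. The step of a number no higher from compound 1 to compound 4 (the limit leaves the size open) is therefore expected to be small or absent. Compound 4 is expected to show about 100000 nM in this assay, with a range from 30000 nM to 300000 nM, and most likely it too will come back only as a limit.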

Compound 4, half-maximal cytotoxic concentration: > 50000 nM
Compound 4: only a limit was reported; the forecaster's own chance of this, stated with the estimate: 75%; the middle value is on the limit's open side.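

For the compounds shown here, compound 1 and compound 4 both returned only a limit of the test, so no step between them can be read. The compounds shown leave open at what concentration any of them would register as toxic in this assay, and whether swapping 2-methoxyphenyl for 3-bromophenyl changes that.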